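This account rests on a few compounds, and the source may have more. Where it says the series, first, only, none or still open, it means among the compounds named here.

Of the compounds shown here, two with a shared core have been measured in an assay on isolated protein for inhibition of histone deacetylase 8 (Homo sapiens), with a stated time of 1 h; on this read-out lower numbers stand for stronger inhibition and higher numbers for weaker inhibition. Compound 1 `O=C(COc1ccc2cc(/C=C3/SC(=O)NC3=O)ccc2c1)Nc1ccccc1` gives 4500 nM in this assay, and compound 2 `Cc1cccc2sc(NC(=O)COc3ccc4cc(/C=C5/SC(=O)NC5=O)ccc4c3)nc12` gives 5800 nM. Among the measured compounds shown here, the one step between them, a 1.3-fold higher number from compound 1 to compound 2 (0.11 log units; within the scatter), is therefore small; the number of compound 2 is the larger of the two, but the margin to compound 1 lies within the scatter, so neither can be called the weaker binder.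

Compound 3 `Cc1ccc(NC(=O)COc2ccc3cc(/C=C4/SC(=O)NC4=O)ccc3c2)cc1Cl` has not yet been measured. It differs from compound 2 by 3-chloro-4-methylphenyl in place of 4-methyl-1,3-benzothiazol-2-yl on an amide-type nitrogen. For the measured compounds named here, the only step that bears on this change is the exchange of an aryl group on the same amide-type nitrogen, from compound 1 to compound 2, which stayed within the scatter. On that basis no shift beyond the scatter is expected in this assay, and compound 3 is estimated at 4600 nM, with a range from 1500 nM to 14000 nM, a step of a 1.3-fold lower number from compound 2 to compound 3 (0.10 log units; within the scatter) from compound 2 being the expectation.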

Compound 3, half-maximal inhibitory concentration: > 50000 nM
Compound 3 gave a limit, no number; the forecaster's own chance of this, stated with the estimate: 5%; middle value at least 10-fold (1.03 log units) from the limit.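

In this assay compound 3 gives only a limit of the assay, not a number: the limit of > 50000 nM in this assay, at which 1 of the 3 values shown sits. Putting 3-chloro-4-methylphenyl on the amide-type nitrogen in place of phenyl gives an at least 11-fold higher number from compound 1 to compound 3 (1.04 log units; beyond the scatter), and in place of 4-methyl-1,3-benzothiazol-2-yl it gives an at least 8.6-fold higher number from compound 2 to compound 3 (0.93 log units; beyond the scatter). Among the compounds shown here, this position therefore does respond to the group it carries, which the single exchange within the scatter among the earlier compounds could not show.

Whether the chlorine, the methyl or only the two together account for this loss stays open. So does how a 4-methylphenyl, a 3-chlorophenyl or a phenyl bearing an amine or a carboxylic acid would read in this assay.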